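Compound 4: phenylsulfonyl for methoxyphenoxy on the chain carbon

The compounds below may be only part of what the source reports. "The series", "measured", "known", "first", "only" and "open" are said of these compounds alone.

Working notes on the series. Compound 1 `N#Cc1ccccc1C1OCC(C/C=C\CCC(=O)O)C(c2cccnc2)O1` gives 54 nM in an assay for inhibition of Thromboxane-A synthase (Homo sapiens), using microsomes; on this read-out higher numbers stand for weaker inhibition and lower numbers for stronger inhibition. Compound 2 `O=C(O)CC/C=C\CC1COC(c2cccs2)OC1c1cccnc1` gives 71 nM in this assay; the step of a 1.3-fold higher number from compound 1 to compound 2 (0.12 log units; within the scatter) concerns the saturated ring carbon and does not rise above the scatter. Compound 3 `COc1ccc(OC(C)(C)C2OCC(C/C=C\CCC(=O)O)C(c3cccnc3)O2)cc1` gives 41 nM in this assay, the lowest of the three numbers, though the gaps to compound 1 and to compound 2 are both within the scatter, so no ranking among the three is supported.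

Compound 4 `CC(C)(C1OCC(C/C=C\CCC(=O)O)C(c2cccnc2)O1)S(=O)(=O)c1ccccc1` has not been measured. It differs from compound 3 as follows: phenylsulfonyl in place of 4-methoxyphenoxy on a saturated chain carbon bound to two saturated chain carbons and a saturated ring carbon. For the measured compounds named here, no measured step touches this chain carbon; the only step available, from compound 1 to compound 2, sits at a different place and was within the scatter. With the three numbers so close to each other, the step to compound 4 is expected to be a 1.2-fold higher number from compound 3 to compound 4 (0.09 log units; within the scatter), none beyond the scatter. Compound 4 is therefore estimated at 50 nM in this assay, with a range from 20 nM to 130 nM.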

Compound 4, half-maximal inhibitory concentration: 40 nM
Compound 4: the middle estimate sits 1.3-fold (0.10 log units) above what was measured, within the range that was stated.
By their numbers in this assay, from the lowest: compounds 4, 3, 1 and 2 (each within the scatter of the next).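

In this assay, for the compounds shown here, phenylsulfonyl in place of 4-methoxyphenoxy on a saturated chain carbon bound to two saturated chain carbons and a saturated ring carbon gives a 1.0-fold lower number from compound 3 to compound 4 (0.01 log units; within the scatter), the first step that can be read at this position. The two groups match in heavy atoms, in their single six-membered aromatic ring of carbon only, and in hydrogen-bond donors and acceptors, but they differ in elements, with sulfur entering and the double bonds outside aromatic rings appearing, and this exchange leaves the number within the scatter. No available evidence accounts for this result.

Still open, going by these compounds, is whether the number holds with a group lacking an aromatic ring at this chain carbon, such as an amine. Equally open, on these data alone, is how the number responds to a primary amide in place of the carboxylic acid.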